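Swapping a nitrile for two chlorines on the benzyl group

This account rests on a few compounds, and the source may have more. Where it says the series, first, only, none or still open, it means among the compounds named here.

Four compounds share one core and differ only in the group hanging from the ring amine nitrogen. Compound 1 `O=c1c2cnn(-c3ccc(F)cc3)c2ncn1CC1(O)CCN(Cc2ccccc2Br)CC1` gives 3100 nM in an assay on Sf21 cells for inhibition of ubiquitin carboxyl-terminal hydrolase 7 (Homo sapiens), read by spectrophotometry, with stated times of 30 min and 2 h; a lower number here means a stronger inhibitor, a higher number a weaker inhibitor. Compound 2 `N#Cc1ccccc1CN1CCC(O)(Cn2cnc3c(cnn3-c3ccc(F)cc3)c2=O)CC1` gives 8100 nM in this assay. Going by the values given here, the step of a 2.6-fold higher number from compound 1 to compound 2 (0.42 log units; beyond the scatter) is the only measured comparison available. For compound 3 `N#Cc1ccc(CN2CCC(O)(Cn3cnc4c(cnn4-c4ccc(F)cc4)c3=O)CC2)cc1` the result in this assay is "not determined" (no result reported), so it stands nowhere on the numbers shown; only its structure is known. Compound 4 `O=c1c2cnn(-c3ccc(F)cc3)c2ncn1CC1(O)CCN(Cc2ccc(Cl)cc2Cl)CC1` is the next compound to be measured, and it differs from compound 3 by 2,4-dichlorophenyl in place of 4-cyanophenyl on a saturated chain carbon bound to an amine nitrogen in a ring.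

Among the compounds with values here, no measured step covers this exact change. The closest guide is the step from compound 1 to compound 2, in which replacing a halogen with a cyano group raised the number by a modest amount, beyond the scatter. Compound 4 carries two halogens and no nitrile, so a number closer to that of compound 1 than that of compound 2 seems the more likely outcome, though without a value for compound 3 the size of the step itself cannot be set. Compound 4 is therefore expected to give roughly 2500 nM in this assay, within a range from 700 nM to 9000 nM.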

Compound 4, half-maximal inhibitory concentration: 3300 nM
Beside the measured number, compound 4's estimate is 1.3-fold (0.12 log units) below it; low and high end bracket the measured number.
By their numbers in this assay, from the lowest: compounds 1 and 4 (each within the scatter of the next); then compound 2.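

Compound 3 has no result in this assay, and the change from 4-cyanobenzyl to 2,4-dichlorobenzyl cannot be read as a step. The other comparisons are readable: putting 2,4-dichlorophenyl in place of 2-bromophenyl gives a 1.1-fold higher number from compound 1 to compound 4 (0.03 log units; within the scatter) and putting it in place of 2-cyanophenyl gives a 2.5-fold lower number from compound 2 to compound 4 (0.39 log units; beyond the scatter) so the two measured halogen-bearing compounds now sit together and the measured nitrile, compound 2, stands apart from both. Nothing measured here explains why the numbers fall this way.

As far as these compounds go, it remains open whether a single chlorine would match the two chlorines of compound 4, and whether moving the nitrile to the 4-cyanophenyl arrangement changes the number. A methoxy group, an amine or a carboxylic acid on the phenyl ring would test whether this picture holds beyond halogens and nitriles.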